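Second chloro on the amine-bearing ring: outlook for compound 3

The compounds below may be only part of what the source reports. "The series", "measured", "known", "first", "only" and "open" are said of these compounds alone.

Compound 1 `Cc1ccccc1Nc1nc(C)c(C(=O)/C=C/c2ccc(Cl)cc2)s1`: in a functional assay on Bel-7402 cells (Homo sapiens) for cytotoxicity, read by MTT assay (on this read-out lower numbers stand for stronger inhibition and higher numbers for weaker inhibition), compound 1 gives > 25000 nM, which is a limit of the assay.
Compound 2 `Cc1nc(Nc2cccc(Cl)c2)sc1C(=O)/C=C/c1ccc(Cl)cc1`: in this assay compound 2 gives > 25000 nM, also a limit.

Compound 2 therefore stands at the limit of this assay, with no number read. Within the data shown here, the single measured step, a step that the two limits leave unreadable from compound 1 to compound 2, cannot be sized because of the limit of > 25000 nM in this assay, at which 2 of the 2 values shown sit. Compound 3 `Cc1nc(Nc2ccc(Cl)c(Cl)c2)sc1C(=O)/C=C/c1ccc(Cl)cc1` differs from compound 2 by chloro in place of hydrogen on an aromatic carbon. No measured step bears on this change, so nothing shown tells how far it moves the read-out. Compound 3 is expected to stay near the limit, with an estimate of 30000 nM ranging from 8000 nM to 100000 nM. That estimate means a step that the limit leaves unreadable from compound 2 to compound 3, most likely reported again as a limit.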

Compound 3, half-maximal inhibitory concentration: > 25000 nM
Compound 3: only a limit was reported; the forecaster's own chance of this, stated with the estimate: 80%; the middle value lies beyond the limit too.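

Compound 1, compound 2 and compound 3 give no readable step, because all three values are limits of the assay: the limit of > 25000 nM in this assay, at which 3 of the 3 values shown sit.

Going by these compounds, whether the 2-methylphenyl, 3-chlorophenyl and 3,4-dichlorophenyl groups differ at all in this assay stays open.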